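The source may report more compounds than this note shows. Statements on the series, on what has been measured and on what is new or still open speak of the compounds shown alone.

In an assay on CHO cells for displacement of a labelled ligand from adenosine receptor A3 (Homo sapiens), read by scintillation counting, with a stated time of 45 min, in the presence of a further agent that is not named here (on this read-out lower numbers stand for stronger inhibition and higher numbers for weaker inhibition), compound 2 `CCCn1c(=O)[nH]c2nc(-c3ccc(S(=O)(=O)N4CCN(Cc5ccc(Br)c(F)c5)CC4)cc3)[nH]c2c1=O` gives only a limit, > 1000 nM. Compound 1 `CCCn1c(=O)[nH]c2nc(-c3ccc(S(=O)(=O)N4CCN(c5ccccc5F)CC4)cc3)[nH]c2c1=O` carries 2-fluorophenyl on the amine nitrogen in the ring where compound 2 carries 4-bromo-3-fluorobenzyl. In this assay compound 1 likewise gives only a limit, > 1000 nM. The step that the two limits leave unreadable from compound 1 to compound 2 is therefore unreadable, since both values sit at the limit of > 1000 nM in this assay, at which 2 of the 2 values shown sit. Compound 3 `CCCn1c(=O)[nH]c2nc(-c3ccc(S(=O)(=O)N4CCN(c5ccccc5)CC4)cc3)[nH]c2c1=O` has not yet been measured; it differs from compound 2 by phenyl in place of 4-bromo-3-fluorobenzyl on an amine nitrogen in a ring. For the measured compounds named here, the single measured step in this assay bears on this change, yet its size cannot be read, so no direction or size beyond the scatter can be drawn from it, and the two limits give no sign that a group on this nitrogen brings the value into the readable range. Compound 3 is therefore expected to give about 3000 nM in this assay, within 800 nM to 15000 nM, and the expected step that the limit leaves unreadable from compound 2 to compound 3 is most likely itself to remain at a limit.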

Compound 3, inhibition constant: > 1000 nM
Compound 3 was reported as a limit; the forecaster's own chance of this, stated with the estimate: 80%; the middle value is on the limit's open side.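

In this assay no step can be read among compound 1, compound 2 and compound 3, since all three give only a limit: the limit of > 1000 nM in this assay, at which 3 of the 3 values shown sit. The compounds shown leave open whether any group on this amine nitrogen in the ring brings the value into the readable range.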